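The compounds below may be only part of what the source reports. "The series", "measured", "known", "first", "only" and "open" are said of these compounds alone.

The measured compounds:
compound 1 `COc1ccc(N/C=N/C2=C(C#N)C3C(N4CCCC4)CCCCN3C(=O)N2c2ccccc2)cc1` gives 37.2% in a functional assay on the whole organism (strain albino) for inhibition, with Rattus norvegicus as the target, read by paw edema, with stated times of 1 h and 2 h, at a dose of 20 mmol/kg by the intraperitoneal route; on this read-out higher numbers stand for more inhibition at the one dose given (going by the name of the read-out) and lower numbers for less inhibition;
compound 2 `N#CC1=C(NCN2CCCCC2)N(c2ccccc2)C(=O)N2CCCCC(N3CCCC3)C12` gives 36.9% in this assay.

For the measured compounds named here, compound 2 stands within the scatter of compound 1, the only other compound measured. Compound 3 `CCOC(=O)C(=O)NC1=C(C#N)C2C(N3CCCC3)CCCCN2C(=O)N1c1ccccc1` differs from compound 2 by (ethoxycarbonyl)carbonyl in place of (piperidin-1-yl)methyl on an amine nitrogen. Going by the values given here, the single measured step, a number 0.3 percentage points lower from compound 1 to compound 2 (within the scatter), concerns a different position on the shared core and lies within the scatter, so no measured step bears directly on the present change. The expected step is a number 1.9 percentage points lower from compound 2 to compound 3 (within the scatter), within the scatter. Compound 3 is therefore expected at 35%, with a range from 18% to 52%.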

Compound 3, a percentage reported as inhibition, in the whole organism at one dose (the size of the read-out at that dose, not a potency): 83.6%
The estimate for compound 3 lay 48.6 percentage points below the measured number; measured number outside the range, above it.
By their numbers in this assay, from the lowest: compounds 2 and 1 (each within the scatter of the next); then compound 3.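

In this assay, the group on this amine nitrogen turns out to matter: (ethoxycarbonyl)carbonyl in place of (piperidin-1-yl)methyl gives a number 46.7 percentage points higher from compound 2 to compound 3 (beyond the scatter), and the comparison with the larger group of compound 1 gives a number 46.4 percentage points higher from compound 1 to compound 3 (beyond the scatter). The earlier pair, though different at this place, had stood within the scatter of each other and gave no sign of such a change. Nothing available here accounts for the rise. From the compounds shown here alone, it remains open whether the rise belongs to the ethyl ester or to the carbonyl on the amine nitrogen; a carboxylic acid or an acetyl group at this place would bear on that.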